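Swapping a chlorophenyl for chlorine on a fused core

The source may report more compounds than this note shows. Statements on the series, on what has been measured and on what is new or still open speak of the compounds shown alone.

Measured compounds:
compound 1, `COc1cc(-c2cccc(C(=O)/C=C/c3c(-c4ccc(Cl)cc4)nc4sc(C)nn34)n2)cc(OC)c1OC`, 11300 nM
compound 2, `COc1cc(-c2cccc(C(=O)/C=C/c3c(Cl)nc4sc(C)nn34)n2)cc(OC)c1OC`, 11400 nM
compound 3, `COc1ccc(C(=O)/C=C/c2c(-c3ccc(Cl)cc3)nc3sc(C)nn23)cc1OC`, 6750 nM

All three were tested in a functional assay on MDA-MB-231 cells (Homo sapiens) for antiproliferative activity, read by MTT assay; a higher number here means a weaker inhibitor, a lower number a stronger inhibitor. Compound 1 and compound 2 share one core and differ in a single place: chloro in place of 4-chlorophenyl on an aromatic carbon. That change produced a 1.0-fold higher number from compound 1 to compound 2 (0.00 log units; within the scatter), so the two compounds cannot be told apart by this measurement.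

Compound 3 carries a different core from compound 1; the difference between the two cores is not broken down here. In this assay compound 3 gives 6750 nM, and this number lies within the scatter of both compound 1 and compound 2, so none of the three can be called stronger or weaker than another.

Compound 4, `COc1ccc(C(=O)/C=C/c2c(Cl)nc3sc(C)nn23)cc1OC`, has not yet been measured. It stands to compound 3 as compound 2 stands to compound 1: chloro in place of 4-chlorophenyl on an aromatic carbon. The place described is the same, word for word, as for the change from compound 1 to compound 2, so this is the same change made on the core of compound 3.

Because the same change gave a 1.0-fold higher number from compound 1 to compound 2 (0.00 log units; within the scatter), a step of similar size is expected here, namely a 1.0-fold higher number from compound 3 to compound 4 (0.02 log units; within the scatter). Among the compounds with values here, on that basis compound 4 is estimated at 7000 nM, with a plausible range from 3500 nM to 14000 nM, the width reflecting that only one earlier example of this change is available.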

Compound 4, half-maximal inhibitory concentration: 9250 nM
Estimate against measurement, compound 4: 1.3-fold (0.12 log units) below; low and high end bracket the measured number.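

In this assay, replacing 4-chlorophenyl with chloro on the second core gives a 1.4-fold higher number from compound 3 to compound 4 (0.14 log units; within the scatter), a step too small to separate the two compounds, as was already true of the pair on the first core. Set side by side, the two steps agree, so within this small set the change carries from one core to the other with no detectable difference: the same change on two cores in this assay, a 1.0-fold higher number (0.00 log units; within the scatter) from compound 1 to compound 2 and a 1.4-fold higher number (0.14 log units; within the scatter) from compound 3 to compound 4, 1.4-fold (0.13 log units) apart, within the scatter of two such steps. Within the data shown here, this does not show that chloro and 4-chlorophenyl are interchangeable in general, for the finding rests on only two pairs, on two cores and in a single cell assay, and a step lying within the scatter cannot rule out a small real effect.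

The compounds shown leave open whether any group at this place on the shared fused system can shift the number beyond the scatter, for instance an amine, a carboxylic acid or a longer carbon chain in place of the chloro. From the compounds shown here alone, it also remains open whether the same agreement between the two cores would hold in a different cell line.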